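Swapping a Methoxy for a Methylsulfonylphenyl Ring

The source may hold more compounds than are shown below. What is called first, only, known or untested is meant among the compounds shown, and "the series" means these compounds.

Compound 1 `COc1cc(C(O)(C(F)(F)F)C(F)(F)F)cnc1N1CCN(S(=O)(=O)c2ccc(N)nc2)CC1`: < 14 mL.min-1.g-1
Compound 2 `Cc1csc(-c2cc(C(O)(C(F)(F)F)C(F)(F)F)cnc2N2CCN(S(=O)(=O)c3ccc(N)nc3)CC2)c1`: 29 mL.min-1.g-1
Compound 3 `Nc1ccc(S(=O)(=O)N2CCN(c3ncc(C(O)(C(F)(F)F)C(F)(F)F)cc3-c3cccc(F)c3)CC2)cn1`: 25 mL.min-1.g-1

In an ADME assay (liver) for metabolic stability, with Liver microsome (Homo sapiens) as the target, using microsomes and NADPH, with a stated time of 30 min, tested at 1 uM (a higher number here means faster removal of the compound, a lower number slower removal), compound 1 sits at the reporting limit: its value < 14 mL.min-1.g-1 is a floor of the assay, not a number, so compound 1 can only be said to be cleared no faster than that floor (the limit of < 14 mL.min-1.g-1 in this assay, at which 1 of the 3 values shown sits). Compound 4 `CS(=O)(=O)c1ccc(-c2cc(C(O)(C(F)(F)F)C(F)(F)F)cnc2N2CCN(S(=O)(=O)c3ccc(N)nc3)CC2)cc1` takes the same core and carries the change (4-(methylsulfonyl)phenyl in place of methoxy on an aromatic carbon). Two measured steps resemble it, both putting an aromatic ring where the methoxy stood: an at least 2.0-fold higher number from compound 1 to compound 2 (0.31 log units; beyond the scatter) and an at least 1.7-fold higher number from compound 1 to compound 3 (0.25 log units; that floor lies within the scatter). Between those two rings the gap is small, a 1.2-fold lower number from compound 2 to compound 3 (0.06 log units; within the scatter). A similar, modest rise is therefore expected for compound 4, an at least 1.4-fold higher number from compound 1 to compound 4 (0.15 log units; that floor lies within the scatter), and its value in this assay is estimated at 20 mL.min-1.g-1, within 10 mL.min-1.g-1 to 40 mL.min-1.g-1.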

Compound 4, intrinsic clearance in microsomes: 32 mL.min-1.g-1
Beside the measured number, compound 4's estimate is 1.6-fold (0.20 log units) below it; measured number inside the range.
By their numbers in this assay, from the lowest: compounds 3, 2 and 4 (each within the scatter of the next). At a limit, below all of these: compound 1.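

In this assay the 4-(methylsulfonyl)phenyl ring in place of methoxy gives a clear rise (an at least 2.2-fold higher number from compound 1 to compound 4 (0.35 log units; beyond the scatter)). Compound 1 stands only as a limit of the assay: the limit of < 14 mL.min-1.g-1 in this assay, at which 1 of the 4 values shown sits. The new ring cannot be told apart from the two earlier rings (a 1.3-fold higher number from compound 3 to compound 4 (0.11 log units; within the scatter)) and (a 1.1-fold higher number from compound 2 to compound 4 (0.04 log units; within the scatter)), so adding a methylsulfonyl group to the ring leaves the number within the scatter of theirs.

As far as these compounds go, whether the rise needs an aromatic ring at all stays open. An amine or a longer alkyl chain in place of the methoxy would test that.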